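Meta-substituent series: chloro to trifluoromethyl on the anilide ring

The source may hold more compounds than are shown below. What is called first, only, known or untested is meant among the compounds shown, and "the series" means these compounds.

The series shares one core, an amide nitrogen carrying a substituted phenyl ring and a cyclopentyl bearing dimethylamino. Compound 1 `CCC(=O)N(c1cccc(C)c1)C1CCCC1N(C)C` carries a methyl on the aromatic ring; in a functional assay on the whole organism for antagonist activity, with Mus musculus as the target (a lower number here means that less compound is needed, a higher number that more compound is needed for the effect), compound 1 gives 1 mg/kg; 1 mg/kg (2 entries). Compound 2 `CCC(=O)N(c1cccc(Cl)c1)C1CCCC1N(C)C` carries chloro in the same place; in this assay compound 2 gives 0.2 mg/kg. On the numbers in hand, compound 2 stands at the lower dose of the two measured compounds, with compound 1 at the higher one; a further entry for compound 2 in this assay carries no single number.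

The next compound, compound 3 `CCC(=O)N(c1cccc(C(F)(F)F)c1)C1CCCC1N(C)C`, differs from compound 2 only at that aromatic carbon: trifluoromethyl in place of chloro on an aromatic carbon.

For the measured compounds named here, no comparable step has been measured within this pair, so the expectation rests on the two values shown. The change from compound 2 to compound 3 is expected to shift the dose by a 2.0-fold higher number from compound 2 to compound 3 (0.30 log units; within the scatter), a small step toward a higher dose that may well sit within the usual scatter. Compound 3 is expected to give 0.4 mg/kg in this assay, with a range from 0.1 mg/kg to 1.5 mg/kg.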

Compound 3, dose for half-maximal effect: 0.2 mg/kg
Compound 3: middle estimate off by 2.0-fold (0.30 log units), on the high side; low and high end bracket the measured number.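

In this assay, trifluoromethyl in place of chloro on an aromatic carbon gives no change at the digits printed from compound 2 to compound 3 (within the scatter), so this position takes a group of 4 heavy atoms as well as one of 1 heavy atom, with no separation between the two in dose. This adds a second group at the low end of the series: compound 1, with methyl at the same carbon, gives 1 mg/kg; 1 mg/kg (2 entries), whereas compound 3 gives 0.2 mg/kg, and the printed values place compound 3 at the lower dose of that pair. Nothing available here accounts for the match between chloro and trifluoromethyl or for the gap in printed values between methyl and trifluoromethyl.

Still open, on these data alone, is how far this tolerance extends at the same aromatic carbon, for example to a methoxy group, a nitrile, an amine or a carboxylic acid. The compounds shown also leave open whether the match between chloro and trifluoromethyl would hold with a longer chain on the amide carbonyl, or with a larger amine in place of dimethylamino on the cyclopentyl.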